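The source may hold more compounds than are shown below. What is called first, only, known or untested is meant among the compounds shown, and "the series" means these compounds.

Measured so far:
compound 1 `COc1cccc(CNCCCNc2ccnc3cc(-c4ccc(C(C)(C)C)cc4)ccc23)c1O`, 237 10^-6 cm/s
compound 2 `CC(C)(C)c1ccc(-c2ccc3c(NCCCNCc4ccco4)ccnc3c2)cc1`, 237 10^-6 cm/s
compound 3 `COc1ccc(F)cc1CNCCCNc1ccnc2cc(CCC(C)C)ccc12`, 23 10^-6 cm/s

In an ADME assay for permeability, using PAMPA, with a stated time of 30 min, at pH 7.4 (a higher number here means that the compound crosses the layer faster, a lower number that the compound crosses the layer more slowly), compound 1 gives 237 10^-6 cm/s, level with compound 2 and together with it the highest of the three numbers; compound 3 sits a long way lower at 23 10^-6 cm/s, but differs from compound 1 in more than one place, so nothing is drawn from that gap.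

Compound 4 `COc1cccc(CNCCCNc2ccnc3cc(Cc4ccc(C#N)cc4)ccc23)c1O` is not yet measured in this assay. It differs from compound 1 in one place: 4-cyanobenzyl in place of 4-(tert-butyl)phenyl on an aromatic carbon.

Within the data shown here, the only single step in the set, no change at the digits printed from compound 1 to compound 2 (within the scatter), touches the amine side, not this aromatic carbon, so no measured step bears on the change. The expectation for compound 4 is therefore guarded, a modest downward step a 2.4-fold lower number from compound 1 to compound 4 (0.37 log units; beyond the scatter), with compound 4 estimated at 100 10^-6 cm/s, between 30 10^-6 cm/s and 250 10^-6 cm/s.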

Compound 4, apparent permeability: 23 10^-6 cm/s
Compound 4: the middle estimate sits 4.3-fold (0.64 log units) above what was measured, and the stated range ends above it.
By their numbers in this assay, from the lowest: compounds 3 and 4 (each within the scatter of the next); then compounds 1 and 2 (each within the scatter of the next).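

In this assay, among these compounds, this aromatic carbon of the shared core proves sensitive to what it carries: 4-cyanobenzyl in place of 4-(tert-butyl)phenyl gives a 10-fold lower number from compound 1 to compound 4 (1.01 log units; beyond the scatter), a large step, while the only earlier single step, on the amine side, stayed within the scatter. Nothing measured here accounts for this drop. The compounds shown leave open which part of the change carries the step, the carbon link of the benzyl or the nitrile. A 4-cyanophenyl or a 4-(tert-butyl)benzyl on the same carbon would separate the two.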